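The source may hold more compounds than are shown below. What is called first, only, known or untested is meant among the compounds shown, and "the series" means these compounds.

Three close relatives share one core and differ only in what hangs from the aniline side. In an ADME assay on isolated protein for inhibition of Dihydrofolate reductase (Homo sapiens), using NADPH (on this read-out lower numbers stand for stronger inhibition and higher numbers for weaker inhibition), compound 1 `Nc1nc(N)c2nc(Nc3ccccc3)ccc2n1` gives 1530 nM, the lowest of the three numbers in hand. Compound 2 `Nc1nc(N)c2nc(Nc3ccc(F)c(F)c3)ccc2n1` gives 2250 nM in this assay, a value that sits within the usual scatter of that of compound 1, so the two cannot be told apart. Among the compounds with values here, compound 3 `Nc1nc(N)c2nc(Nc3ccc(OC(F)(F)F)cc3)ccc2n1` gives 4130 nM, and the step of a 2.7-fold higher number from compound 1 to compound 3 (0.43 log units; beyond the scatter) is the only measured step that crosses the scatter.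

Compound 4 `CCN(c1ccccc1)c1ccc2nc(N)nc(N)c2n1` differs from compound 1 by ethyl in place of hydrogen on a nitrogen on an aromatic ring. Within the data shown here, no measured step touches this nitrogen; the single step in hand concerns a group on an aromatic carbon and weakened inhibition only modestly, so it offers no direct guide. With nothing pointing clearly either way, the step of a 1.2-fold lower number from compound 1 to compound 4 (0.07 log units; within the scatter) is expected to stay within the scatter. Compound 4 is therefore estimated at 1300 nM in this assay, with a range from 400 nM to 4500 nM.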

Compound 4, half-maximal inhibitory concentration: 1570 nM
The estimate for compound 4 lay 1.2-fold (0.08 log units) below the measured number; the measured number falls inside the stated range.
By their numbers in this assay, from the lowest: compounds 1, 4, 2 and 3 (each within the scatter of the next, the first and the last beyond it).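

Within the data shown here, compound 4 is the first in the set changed at the nitrogen on an aromatic ring rather than on an aromatic carbon, and in this assay ethyl in place of hydrogen there gives a 1.0-fold higher number from compound 1 to compound 4 (0.01 log units; within the scatter). This nitrogen can therefore lose its hydrogen and carry ethyl without any change that can be told from the scatter, unlike the step to trifluoromethoxy on an aromatic carbon, a 2.7-fold higher number from compound 1 to compound 3 (0.43 log units; beyond the scatter). Nothing measured here explains why the number holds steady.

Ethyl is the only group shown on this nitrogen, so it remains open whether methyl, a longer chain such as butyl, or a carboxylic acid on a chain would be tolerated as well. Also open, from the compounds shown here alone, is whether ethyl would have the same small effect in compound 3, with its trifluoromethoxy group.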